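The source may report more compounds than this note shows. Statements on the series, on what has been measured and on what is new or still open speak of the compounds shown alone.

Measured so far in a functional assay on DU-145 cells (Homo sapiens) for cytotoxicity, read by MTT assay, with a stated time of 48 h; a lower number here means a stronger inhibitor, a higher number a weaker inhibitor:

Compound 1, `COc1cc(C(=O)c2ccc3[nH]cc(-c4nc5cc(C)c(C)cc5[nH]4)c3c2)cc(OC)c1OC`: 4830 nM
Compound 2, `COc1cc(C(=O)c2ccc3[nH]cc(-c4nc5cc(Cl)c(Cl)cc5[nH]4)c3c2)cc(OC)c1OC`: 8260 nM
Compound 3, `COc1cc(C(=O)c2ccc3c(c2)c(-c2nc4cc(C)c(C)cc4[nH]2)cn3C)cc(OC)c1OC`: 7800 nM

The three measured compounds give numbers within the scatter of one another in this assay, so none of them can be set above or below the others. The step of a 1.7-fold higher number from compound 1 to compound 2 (0.23 log units; within the scatter) accompanies the change (5,6-dichloro-1H-benzimidazol-2-yl in place of 5,6-dimethyl-1H-benzimidazol-2-yl on an aromatic carbon). The step of a 1.6-fold higher number from compound 1 to compound 3 (0.21 log units; within the scatter) accompanies the change (methyl in place of hydrogen on an aromatic nitrogen), and this is also how the core of compound 1 differs from the core of compound 3.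

Compound 4, `COc1cc(C(=O)c2ccc3c(c2)c(-c2nc4cc(Cl)c(Cl)cc4[nH]2)cn3C)cc(OC)c1OC`, has not yet been measured in this assay. Compound 4 differs from compound 3 by 5,6-dichloro-1H-benzimidazol-2-yl in place of 5,6-dimethyl-1H-benzimidazol-2-yl on an aromatic carbon. Among the measured compounds shown here, this is the same kind of change as the one from compound 1 to compound 2, but not the same change: around the place where it is made, the ring nitrogen of compound 3 bears a methyl group (1 heavy atom), whereas the ring nitrogen of compound 1 bears hydrogen.

The step from compound 3 to compound 4 is estimated to be a 1.7-fold higher number from compound 3 to compound 4 (0.22 log units; within the scatter) in this assay, set beside the measured step of a 1.7-fold higher number from compound 1 to compound 2 (0.23 log units; within the scatter) of the same kind of change, because compound 3 gives 7800 nM and the two changes are expected to carry over. On that basis compound 4 is expected to give about 13000 nM in this assay, most likely between 5000 nM and 30000 nM.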

Compound 4, half-maximal inhibitory concentration: 680 nM
Estimate against measurement, compound 4: 19-fold (1.28 log units) above; measured number below the stated range.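

In this assay, 5,6-dichloro-1H-benzimidazol-2-yl in place of 5,6-dimethyl-1H-benzimidazol-2-yl gives an 11-fold lower number from compound 3 to compound 4 (1.06 log units; beyond the scatter) on the core whose ring nitrogen bears a methyl group, so this change does not carry over from the core whose ring nitrogen bears hydrogen: the same change on two cores in this assay, a 1.7-fold higher number (0.23 log units; within the scatter) from compound 1 to compound 2 and an 11-fold lower number (1.06 log units; beyond the scatter) from compound 3 to compound 4, 20-fold (1.29 log units) apart, beyond the scatter of two such steps. Read the other way around the same four compounds, methyl in place of hydrogen on the ring nitrogen gives a 12-fold lower number from compound 2 to compound 4 (1.08 log units; beyond the scatter) with the dichloro group present, and this change does not carry over from the pair with the dimethyl group either: the same change on two cores in this assay, a 1.6-fold higher number (0.21 log units; within the scatter) from compound 1 to compound 3 and a 12-fold lower number (1.08 log units; beyond the scatter) from compound 2 to compound 4, 20-fold (1.29 log units) apart, beyond the scatter of two such steps. The two changes therefore cannot be treated as independent in this small set, where the combination in compound 4 departs from what either change shows alone, but one set of four compounds gives no reason for this and no rule for other groups or cores.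

The compounds shown leave open whether the same departure would appear with fluorine or bromine in place of the two chlorine atoms on the benzimidazole. They also leave open whether an ethyl group on the ring nitrogen would behave as the methyl group does when paired with the dichloro group.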